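The source may hold more compounds than are shown below. What is called first, only, known or untested is meant among the compounds shown, and "the series" means these compounds.

Measured so far in an ADME assay on microsomes from liver (Homo sapiens) for metabolic stability, read by LC-MS, using NADPH, with stated times of 5 min and 30 min, tested at 1 uM; a lower number here means slower removal, a higher number faster removal of the compound:
- compound 1, `CN(c1ccn(C)n1)c1cnc(NCc2c(F)ccc3c2CCO3)c2cn[nH]c(=O)c12`: 62 mL.min-1.g-1
- compound 2, `Cc1nccn1-c1cnc(NCc2c(F)ccc3c2CCO3)c2cn[nH]c(=O)c12`: 8 mL.min-1.g-1
- compound 3, `CN(C)C(=O)c1cc(-c2cnc(NCc3c(F)ccc4c3CCO4)c3cn[nH]c(=O)c23)n(C)n1`: 21 mL.min-1.g-1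

Among these three numbers, compound 1 stands highest, so it is the one removed fastest by the liver microsomes. The nearest of the two measured steps is a 3.0-fold lower number from compound 1 to compound 3 (0.47 log units; beyond the scatter); the larger is a 7.8-fold lower number from compound 1 to compound 2 (0.89 log units; beyond the scatter).

Compound 4, `Cc1cc(-c2cnc(NCc3c(F)ccc4c3CCO4)c3cn[nH]c(=O)c23)n(C)n1`, is not yet measured. It differs from compound 1 in one place: 1,3-dimethyl-1H-pyrazol-5-yl in place of methyl(1-methyl-1H-pyrazol-3-yl)amino on an aromatic carbon. Both measured steps away from compound 1 share the same pattern as this change: the methyl(1-methyl-1H-pyrazol-3-yl)amino group leaves and a directly attached five-membered ring enters, and in both cases the number fell by a modest amount beyond the scatter. The group entering in compound 4 most closely resembles the 3-(dimethylcarbamoyl)-1-methyl-1H-pyrazol-5-yl of compound 3, so a step of roughly that size in the same direction is expected, estimated as a 3.1-fold lower number from compound 1 to compound 4 (0.49 log units; beyond the scatter). Compound 4 is therefore estimated at 20 mL.min-1.g-1, with a range from 9 mL.min-1.g-1 to 45 mL.min-1.g-1.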

Compound 4, intrinsic clearance in microsomes: 24 mL.min-1.g-1
For compound 4 the middle estimate is 1.2-fold (0.08 log units) below the measured one; measured number inside the range.
By their numbers in this assay, from the lowest: compound 2; then compounds 3 and 4 (each within the scatter of the next); then compound 1.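

In this assay, replacing the methyl(1-methyl-1H-pyrazol-3-yl)amino group with 1,3-dimethyl-1H-pyrazol-5-yl also gives a clear fall (a 2.6-fold lower number from compound 1 to compound 4 (0.41 log units; beyond the scatter)), so all three directly attached five-membered rings shown here stand below compound 1. On the pyrazole ring, a methyl and a dimethylcarbamoyl group cannot be told apart (a 1.1-fold higher number from compound 3 to compound 4 (0.06 log units; within the scatter)), which shows that this large change of substituent left the number within the scatter. The choice of attached ring does show, with the 2-methyl-1H-imidazol-1-yl ring of compound 2 remaining lowest (a 3.0-fold higher number from compound 2 to compound 4 (0.48 log units; beyond the scatter)).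

Nothing measured here explains why these numbers move. From the compounds shown here alone, it remains open whether a pyrazole ring carrying an amine or a carboxylic acid in place of that methyl would also stay within the scatter of compound 4.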